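The source may hold more compounds than are shown below. What is called first, only, known or untested is meant among the compounds shown, and "the series" means these compounds.

The set comprises compound 1 `CCO/N=C/Nc1cc(Cl)c(CC)c(Cl)c1`, compound 2 `C#CCOc1c(Cl)cc(N/C=N/OCC)cc1Cl`, compound 3 `C#CCc1c(Cl)cc(N/C=N/OCCC)cc1Cl` and the as yet unmeasured compound 4 `C#CCc1c(Cl)cc(N/C=N/OC/C=C\Cl)cc1Cl`, all sharing the same core. In a physicochemical assay for lipophilicity, measured as octanol-water partition (on this read-out lower numbers stand for lower lipophilicity and higher numbers for higher lipophilicity), compound 1 gives 4.8. In this assay compound 2 gives 3.6. In this assay compound 3 gives 4, the second highest of the three numbers: it sits beyond the scatter below compound 1 and beyond the scatter above compound 2. Compound 4 differs from compound 3 in one place: 2-chloroethenyl in place of ethyl on a saturated chain carbon bound to an oxygen. Among the compounds with values here, the only step measured between compounds that differ in a single place is a number 1.20 log units lower from compound 1 to compound 2 (beyond the scatter); it concerns a propargyloxy group entering on an aromatic carbon and thus covers neither a change on a saturated chain carbon bound to an oxygen nor the entry of a chlorine. Within the data shown here, no measured step therefore bears directly on the change leading to compound 4, and the expectation rests on the number of compound 3 alone. In this assay compound 4 is expected to move modestly upward, a number 0.30 log units higher from compound 3 to compound 4 (within the scatter). For compound 4 the estimate in this assay is 4.3, with a range from 3.9 to 4.7.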

Compound 4, partition coefficient: 3.9
The estimate for compound 4 lay 0.40 log units above the measured number, within the range that was stated.
By their numbers in this assay, from the lowest: compounds 2, 4 and 3 (each within the scatter of the next, the first and the last beyond it); then compound 1.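

Swapping ethyl for 2-chloroethenyl on a saturated chain carbon bound to an oxygen gives, in this assay, a number 0.10 log units lower from compound 3 to compound 4 (within the scatter), which is the first reading of any change at this position. Within the data shown here, the one earlier step, a number 1.20 log units lower from compound 1 to compound 2 (beyond the scatter), concerned an aromatic carbon and was large, whereas here the propoxy and (3-chloroprop-2-en-1-yl)oxy chains cannot be told apart in this assay, even though the entering group brings a chlorine and a double bond outside aromatic rings. Nothing at hand accounts for this result.

The compounds shown leave open whether the same holds for other groups at this position, such as a longer saturated chain, a hydroxyl group, an amine or a carboxylic acid, since a single step cannot describe how much room this place has for change in this assay. They also leave open whether the chlorine and the double bond would each give the same outcome alone, and whether the swap would read the same on the core of compound 1 or compound 2, which carry ethyl and propargyloxy groups on the aromatic carbon.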